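The source may hold more compounds than are shown below. What is called first, only, known or untested is meant among the compounds shown, and "the series" means these compounds.

Measured in a physicochemical assay for lipophilicity, using the shake flask method, at pH 7.4; a higher number here means a more lipophilic compound, a lower number a more polar compound:
- compound 1 `CC(=O)N1CCN([C@H]2CC[C@H](Nc3ncnn4ccc(C(C)C)c34)CC2)CC1`: 2.4
- compound 2 `CC(C)c1ccn2ncnc(N[C@H]3CC[C@H](N(C)C)CC3)c12`: 1.3

Compound 1 holds the higher of the two numbers. Among the measured compounds shown here, the only measured step is a number 1.10 log units lower from compound 1 to compound 2 (beyond the scatter). It is large, but it replaces the whole 4-acetylpiperazin-1-yl with dimethylamino on a saturated ring carbon, so it bears only loosely on the change below.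

Not yet measured is compound 3 `COC(=O)N1CCN([C@H]2CC[C@H](Nc3ncnn4ccc(C(C)C)c34)CC2)CC1`. It differs from compound 1 in one group: methoxy in place of methyl on a carbonyl carbon. For the measured compounds named here, no measured step isolates this change. The expectation therefore rests on the structural change alone, and a modest rise in this assay is expected, much smaller than the step of a number 1.10 log units lower from compound 1 to compound 2 (beyond the scatter). The expected step is a number 0.40 log units higher from compound 1 to compound 3 (beyond the scatter). The estimate for compound 3 is 2.8, with an expected range of 2.4 to 3.2.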

Compound 3, distribution coefficient: 3.3
For compound 3 the middle estimate is 0.50 log units below the measured one; the whole stated range lies below it.
By their numbers in this assay, from the lowest: compound 2; then compound 1; then compound 3.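

In this assay, exchanging only methyl for methoxy on a carbonyl carbon whose other neighbours are an amide-type nitrogen in a ring gives a number 0.90 log units higher from compound 1 to compound 3 (beyond the scatter) in a single change of one group. The earlier step, a number 1.10 log units lower from compound 1 to compound 2 (beyond the scatter), replaced the whole 4-acetylpiperazin-1-yl and so said nothing about this carbonyl carbon alone; the new step shows that the number moves beyond the scatter with an edit confined to this place, even though the entering methoxy counts one hydrogen-bond acceptor where methyl counts none. No measured evidence at hand accounts for the direction or size of this step.

From the compounds shown here alone, whether a longer chain such as ethoxy on the same carbonyl carbon would extend the step remains open. So does the outcome with an amine such as dimethylamino there, which would show whether the step is specific to methoxy.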